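Hydroxamic acid chain extension on the decyl benzofuran core

The source may hold more compounds than are shown below. What is called first, only, known or untested is meant among the compounds shown, and "the series" means these compounds.

Measured so far:
compound 1, `CCCCCCCCCCc1cc2cc(C(C)N(O)C(C)=O)ccc2o1` — 410 nM
compound 2, `COc1cccc(OC)c1C(=O)N(O)C(C)c1ccc2oc(-c3ccccc3)cc2c1` — 3000 nM

In an assay on RBL cells for inhibition of Polyunsaturated fatty acid 5-lipoxygenase (Rattus norvegicus) (a lower number here means a stronger inhibitor, a higher number a weaker inhibitor), compound 1 gives 410 nM and holds the lowest number of the two measured. Compound 2, which carries a different acyl group on the hydroxamic nitrogen and a different substituent on the shared core, gives 3000 nM in this assay, a clearly higher number than compound 1 and beyond the scatter. Among the compounds with values here, no pair of measured compounds differs in a single place, so no clean step is available from these two values alone.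

Compound 3, `CCCCCCCCCCc1cc2cc(C(C)N(O)C(=O)CCCC(=O)OC)ccc2o1`, is not yet measured. It differs from compound 1 only at the acyl group of the hydroxamic acid: 2-(methoxycarbonyl)ethyl in place of hydrogen on a saturated chain carbon bound to a carbonyl carbon. The decyl chain and the core of compound 1 are kept unchanged.

Within the data shown here, with no measured step to lean on, the expectation for compound 3 in this assay is a modest move toward a higher number, a 2.0-fold higher number from compound 1 to compound 3 (0.29 log units; within the scatter), with the outcome possibly still inside the scatter. Compound 3 is therefore estimated at 800 nM in this assay, within a range from 250 nM to 2500 nM.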

Compound 3, half-maximal inhibitory concentration: 150 nM
For compound 3 the middle estimate is 5.3-fold (0.73 log units) above the measured one; measured number below the stated range.
By their numbers in this assay, from the lowest: compound 3; then compound 1; then compound 2.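

In this assay the change from acetyl to (3-(methoxycarbonyl)propyl)carbonyl on the hydroxamic nitrogen gives a 2.7-fold lower number from compound 1 to compound 3 (0.44 log units; beyond the scatter) with the decyl chain and the shared core unchanged. Within the data shown here, this is the first single-place comparison, and it shows that this position accepts a much larger acyl group than the acetyl of compound 1 without a move toward a higher number, with the longer ester-bearing chain instead giving the lowest number so far. No measurement shown here accounts for the size or direction of this step.

From the compounds shown here alone, whether the step comes from the chain length or from the terminal methyl ester stays open; a carboxylic acid in place of the methyl ester, or an unbranched alkyl chain of the same length, would separate the two. Compound 2 differs from compound 1 in more than one place, so it gives no reading on this acyl position, and whether the step carries over to a core bearing a group other than decyl also remains unsettled.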